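The compounds below may be only part of what the source reports. "The series", "measured", "known", "first", "only" and "open" are said of these compounds alone.

Compound 1 `O=C1c2c[n+]([O-])c3ccccc3c2C(=O)c2[nH]c3ccccc3c21` serves as the starting point. In a toxicity assay on L02 cells (Homo sapiens) for cytotoxicity, read by MTT assay, with a stated time of 72 h (on this read-out higher numbers stand for weaker inhibition and lower numbers for stronger inhibition), compound 1 gives 400 nM, which places it at the low end of the numbers shown. Compound 3 `O=C1c2c[n+]([O-])c3ccccc3c2C(=O)c2c1c1ccccc1n2Cc1cn([C@@H]2O[C@H](CO)[C@@H](O)[C@H](O)[C@H]2O)nn1`, carrying a glycosyl-substituted triazolylmethyl group on the same aromatic nitrogen, gives 420 nM in this assay, a number within the scatter of compound 1. Compound 2 `CC1(C)OC[C@@H](Cn2cc(Cn3c4c(c5ccccc53)C(=O)c3c[n+]([O-])c5ccccc5c3C4=O)nn2)O1`, with an acetonide-protected diol on that triazole, gives 2900 nM in this assay, beyond the scatter of compound 1. Among the compounds with values here, the one step between compounds differing in a single place is a 6.9-fold lower number from compound 2 to compound 3 (0.84 log units; beyond the scatter).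

Compound 4 `O=C1c2c[n+]([O-])c3ccccc3c2C(=O)c2c1c1ccccc1n2Cc1cn(C[C@H](O)CO)nn1` is the next case. Its change from compound 1 is (1-(2,3-dihydroxypropyl)-1H-1,2,3-triazol-4-yl)methyl in place of hydrogen on an aromatic nitrogen. Compound 1 and compound 3 show that adding a hydroxyl-rich triazolylmethyl group to that nitrogen leaves the number essentially unchanged, while compound 2 shows that masking the hydroxyls raises it. Since compound 4 keeps free hydroxyls, the expected step of a 1.5-fold higher number from compound 1 to compound 4 (0.18 log units; within the scatter) is small, at most a modest rise. The estimate for compound 4 in this assay is 600 nM, within 250 nM to 1500 nM.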

Compound 4, half-maximal inhibitory concentration: 1130 nM
Estimate against measurement, compound 4: 1.9-fold (0.27 log units) below; low and high end bracket the measured number.
By their numbers in this assay, from the lowest: compounds 1 and 3 (each within the scatter of the next); then compound 4; then compound 2.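

On this aromatic nitrogen, a triazolylmethyl group with free hydroxyls does not by itself hold the number at the level of compound 1: in this assay the dihydroxypropyl version gives a 2.8-fold higher number from compound 1 to compound 4 (0.45 log units; beyond the scatter) and so parts from what compound 3 had suggested. The group carried on the triazole therefore counts, as the exchange of the sugar ring for 2,3-dihydroxypropyl gives a 2.7-fold higher number from compound 3 to compound 4 (0.43 log units; beyond the scatter) and opening the acetonide gives a 2.6-fold lower number from compound 2 to compound 4 (0.41 log units; beyond the scatter) in the other direction, which leaves compound 4 between the two. Nothing measured here accounts for these differences.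

The compounds shown leave open how the number would respond to an amine, a carboxylic acid or a longer carbon chain on the triazole. They also leave open whether the opposite configuration at the stereocentre of the 2,3-dihydroxypropyl group would change the number.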